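Methyl on the pyridine ring of a thiosemicarbazone

A few compounds are considered here, and "the series" means these few. Any claim that something is new, unique, unknown or untested is made for them only; others in the source may bear on it.

Measured so far:
- compound 1, `N/C(=N\NC(=S)N1CCCCCC1)c1ccccn1`: 56%
- compound 2, `Cc1ccnc(/C(N)=N/NC(=S)N2CCOCC2)c1`: 5.07%

Both compounds were tested in a functional assay on MCF7 cells (Homo sapiens) for cytotoxicity, read by MTT assay, with a stated time of 72 h, tested at 3 uM; a lower number here means less inhibition of growth, a higher number more inhibition of growth at the concentration tested. Compound 1 gives 56%, the higher of the two numbers. Compound 2 gives 5.07%, a number far enough below that of compound 1 to lie beyond the scatter. Compound 2 differs from compound 1 in more than one place, so its value says nothing on its own about any single change.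

Compound 3, `Cc1ccnc(/C(N)=N/NC(=S)N2CCCCCC2)c1`, is not yet measured. It differs from compound 1 in one place: methyl in place of hydrogen on an aromatic carbon. Going by the values given here, no pair of measured compounds shows this change alone, so nothing here tells how large its effect is. A change of one small group on the core is expected to give a modest step, and the step is expected to be a decrease, as a number 14 percentage points lower from compound 1 to compound 3 (beyond the scatter). For compound 3 the value in this assay is therefore estimated at 42%, with a range from 12% to 68%.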

Compound 3, percent growth inhibition at one concentration: 36.3%
Compound 3: middle estimate off by 5.7 percentage points, on the high side; the range from low to high includes it.
By their numbers in this assay, from the lowest: compound 2; then compound 3; then compound 1.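

In this assay, the change of methyl in place of hydrogen on an aromatic carbon, opposite the ring nitrogen, now has a measured size: a number 19.7 percentage points lower from compound 1 to compound 3 (beyond the scatter), a modest step that lies beyond the usual scatter. The position therefore does respond to this single added carbon, yet the response is no collapse, since compound 3 still gives 36.3% at the one concentration tested. Nothing shown here gives a measured reason for this step.

This is a single pair, so it cannot tell whether methyl would have the same effect on a compound with a different group on the thiocarbonyl end of the molecule. It also leaves open how this place on the ring would respond to other groups, such as a chlorine atom, a methoxy group, an amine or a longer chain like ethyl, and whether any of them would keep the growth inhibition closer to that of compound 1.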